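A Methyl Group Takes the Place of a Nitro Group

This account rests on a few compounds, and the source may have more. Where it says the series, first, only, none or still open, it means among the compounds named here.

Compound 1 `O=c1cc(-c2ccccc2)oc2cc(N3COc4c(cccc4[N+](=O)[O-])C3)ccc12`: "not active" (no number reported)
Compound 2 `O=c1cc(-c2ccccc2)oc2ccc(N3COc4ccccc4C3)cc12`: 8.7%
Compound 3 `O=c1cc(-c2ccccc2)oc2cc(N3COc4c(Cl)cc(Cl)cc4C3)ccc12`: "not active" (no number reported)

Three compounds of this series have been examined in a functional assay on MCF7 cells (Homo sapiens) for inhibition, read by MTT assay, with a stated time of 48 h, tested at 7.5 ug/mL; on this read-out lower numbers stand for less inhibition of growth and higher numbers for more inhibition of growth at the one concentration tested. Compound 1 stands without a single number: in this assay compound 1 is recorded as "not active" (no number reported), and compound 3 is the one further entry of the same kind, recorded in this assay as "not active" (no number reported). Only compound 2 carries a figure, giving 8.7% in this assay, a small value on this read-out. Between compound 1 and compound 2, or between compound 1 and compound 3, no step is worked out, as the structures differ in more than one place; their values show only that all three sit at the low end of the scale.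

Compound 4 `Cc1cccc2c1OCN(c1ccc3c(=O)cc(-c4ccccc4)oc3c1)C2` is the next compound to be measured. It differs from compound 1 by methyl in place of nitro on an aromatic carbon. Among the compounds with values here, with no step between measured compounds available, and with compound 2 at 8.7% as the only numerical anchor, no movement beyond the scatter is expected in this assay for this exchange. Compound 4 is therefore estimated to give 8% in this assay, with an expected range from 0% to 25%.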

Compound 4, percent growth inhibition at one concentration: 43.9%
Estimate against measurement, compound 4: 35.9 percentage points below; the measured number lies above the stated range.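

Within the data shown here, compound 4 gives 43.9% in this assay while compound 1 stands as "not active" (no number reported) so no step for methyl in place of nitro can be read between the two. No measured evidence bears on this result. The compounds shown leave open how large that exchange is in figures, and whether it would carry over to other compounds of the series.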